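The source may report more compounds than this note shows. Statements on the series, on what has been measured and on what is new or still open speak of the compounds shown alone.

In a physicochemical assay for solubility, in the presence of a further agent that is not named here (on this read-out lower numbers stand for lower solubility and higher numbers for higher solubility), compound 1 (`[O-][n+]1nc(NCCn2cccc2)[n+]([O-])c2ccccc21`) gives 61000000 nM. Compound 2 (`[O-][n+]1nc(NCCN2CCCCC2)[n+]([O-])c2ccccc21`) gives only a limit, > 49000000 nM. Compound 3 (`CCCN(CCC)CCNc1n[n+]([O-])c2ccccc2[n+]1[O-]`) also gives only a limit, > 25000000 nM, so its true position on the scale is not known.

The next compound, compound 4 (`CCCN(CCC)CCNc1n[n+]([O-])c2ccc(C(C)(C)C)cc2[n+]1[O-]`), differs from compound 3 in one place: tert-butyl in place of hydrogen on an aromatic carbon. This puts tert-butyl in place of hydrogen on an aromatic carbon of the core, while the dipropylamino chain stays as it is.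

The measured steps offer little guidance. There is a step that the limit leaves unreadable from compound 1 to compound 2, then a step that the limit leaves unreadable from compound 1 to compound 3, and finally a step that the two limits leave unreadable from compound 2 to compound 3. All three swap the group at the end of the chain, none touches an aromatic carbon, and none has a size that can be read. Among the measured compounds shown here, no measured compound carries a tert-butyl group, so any forecast here is a judgement and not a calculation.

The expectation is a moderate move toward lower numbers in this assay, though a further limit remains possible. The expected change is an at least 2.0-fold lower number from compound 3 to compound 4 (0.31 log units; beyond the scatter). For compound 4 the estimate is 12000000 nM, with an expected range from 3000000 nM to 40000000 nM.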

Compound 4, solubility: 32000000 nM
Estimate against measurement, compound 4: 2.7-fold (0.43 log units) below; low and high end bracket the measured number.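

In this assay no step can be read between compound 3 and compound 4, as compound 3 stands only as a limit, not a number: the limit of > 25000000 nM in this assay, at which 1 of the 4 values shown sits. The compounds shown leave open where compound 3 truly sits on this scale, and so whether tert-butyl in place of hydrogen on an aromatic carbon raises the number, lowers it or leaves it unchanged.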